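A few compounds are considered here, and "the series" means these few. Any claim that something is new, unique, unknown or untested is made for them only; others in the source may bear on it.

Measured compounds:
compound 1 `Cc1cc(NC(=O)c2ccc(Cl)cc2)ccc1NS(C)(=O)=O` gave 69100 nM
compound 2 `Cc1cc(NC(=O)c2cccc(C(F)(F)F)c2)ccc1NS(C)(=O)=O` gave 110000 nM
compound 3 `CCS(=O)(=O)Nc1ccc(NC(=O)c2ccc(Cl)cc2)cc1C` gave 68700 nM

The three measured compounds were tested in an ADME assay on RAW264.7 cells (Mus musculus) for cytotoxicity, read by MTT assay, with a stated time of 48 h; on this read-out lower numbers stand for stronger inhibition and higher numbers for weaker inhibition. Compound 1 and compound 3 share one core, and compound 3 differs from compound 1 only by the change (methyl in place of hydrogen on a saturated chain carbon bound to a sulfonyl sulfur). Across this pair the read-out hardly moved: a 1.0-fold lower number from compound 1 to compound 3 (0.00 log units; within the scatter). Compound 2 carries a different core, and the difference between the two cores is not broken down here. In this assay compound 2 gives 110000 nM, while compound 1 gives 69100 nM; these two numbers lie within the scatter of each other, and the same is true of compound 2 against compound 3, so no ordering among the three can be claimed.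

Compound 4 `CCS(=O)(=O)Nc1ccc(NC(=O)c2cccc(C(F)(F)F)c2)cc1C` has not yet been measured. It stands to compound 2 exactly as compound 3 stands to compound 1, by the change (methyl in place of hydrogen on a saturated chain carbon bound to a sulfonyl sulfur), which is the same change made at the same place. For the measured compounds named here, since that change left the read-out in place when it was made from compound 1 to compound 3, the step from compound 2 to compound 4 is expected to be of the same small size, no change at the digits printed from compound 2 to compound 4 (within the scatter), a step that rests on a 1.0-fold lower number from compound 1 to compound 3 (0.00 log units; within the scatter) and on no other measured pair. Going by the values given here, only one earlier instance of this change exists among the measured compounds. Compound 4 is therefore estimated at 110000 nM in this assay, with a likely range from 55000 nM to 220000 nM.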

Compound 4, half-maximal inhibitory concentration: 114000 nM
Compound 4: middle estimate off by 1.0-fold (0.02 log units), on the low side; the measured number falls inside the stated range.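

In this assay, the methylsulfonyl to ethylsulfonyl change on the core of compound 2 gives a 1.0-fold higher number from compound 2 to compound 4 (0.02 log units; within the scatter), and this step can be set directly beside the one seen earlier on the core of compound 1. The two steps agree, so in this small set the change carries from one core to the other without a difference that can be told from the scatter: the same change on two cores in this assay, a 1.0-fold lower number (0.00 log units; within the scatter) from compound 1 to compound 3 and a 1.0-fold higher number (0.02 log units; within the scatter) from compound 2 to compound 4, 1.0-fold (0.02 log units) apart, within the scatter of two such steps. This shows only that methyl in place of hydrogen on a saturated chain carbon bound to a sulfonyl sulfur left the read-out in place on these two cores in this one cell assay, and two pairs cannot show that the same would hold on any further core or in any other assay.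

The compounds shown leave open how far this tolerance extends along the chain, since methyl and ethyl are the only groups seen at this place, and a longer chain such as propyl or a branched one such as isopropyl could behave differently. They also leave open whether a chain ending in an amine or a carboxylic acid, or a phenyl ring on the sulfonyl sulfur, would leave the read-out where it stands.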